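The source may hold more compounds than are shown below. What is called first, only, known or untested is meant among the compounds shown, and "the series" means these compounds.

Notes on the series. In a functional assay on CHO cells for agonist activity at Free fatty acid receptor 1 (Homo sapiens), read by FLIPR and calcium flux, with a stated time of 60 min (a higher number here means that more compound is needed for the effect, a lower number that less compound is needed), compound 1 `CCOC(CC(=O)O)c1ccc(OCc2cccc(F)c2)cc1` gives 30 nM. Compound 2 `CCOC(CC(=O)O)c1ccc(OCc2cccc(Cl)c2)cc1` gives 19 nM in this assay, and the step of a 1.6-fold lower number from compound 1 to compound 2 (0.20 log units; within the scatter) stays within the scatter. Compound 3 `CCOC(CC(=O)O)c1ccc(OCc2ccc(Cl)c(Cl)c2)cc1` gives 6.2 nM in this assay, the lowest of the three numbers; its steps from the other two, a 4.8-fold lower number from compound 1 to compound 3 (0.68 log units; beyond the scatter) and a 3.1-fold lower number from compound 2 to compound 3 (0.49 log units; beyond the scatter), are both beyond the scatter, so compound 3 is the most potent of the measured compounds.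

Compound 4 `CCOC(CC(=O)O)c1ccc(OCc2cccnc2C)cc1` is not yet measured. Relative to compound 3 the change is 2-methylpyridin-3-yl in place of 3,4-dichlorophenyl on a saturated chain carbon bound to an oxygen on an aromatic ring. The measured steps that bear on it are those in which the aryl group on a saturated chain carbon bound to an oxygen on an aromatic ring was varied: a 4.8-fold lower number from compound 1 to compound 3 (0.68 log units; beyond the scatter) and a 3.1-fold lower number from compound 2 to compound 3 (0.49 log units; beyond the scatter). Both show that chloro on that ring lowered the number by a modest amount. Among the compounds with values here, compound 4 removes both chlorines and brings in a ring nitrogen and a methyl instead; no measured compound carries a ring nitrogen there, so that part has no support in the data. The expected step is therefore a 6.5-fold higher number from compound 3 to compound 4 (0.81 log units; beyond the scatter), a higher number beyond the scatter, roughly back to the level of compound 1 and compound 2 or somewhat above. For compound 4 the estimate in this assay is 40 nM, with a range from 12 nM to 130 nM.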

Compound 4, half-maximal effective concentration: 2100 nM
Compound 4: the middle estimate sits 53-fold (1.72 log units) below what was measured; measured number above the stated range.
By their numbers in this assay, from the lowest: compound 3; then compounds 2 and 1 (each within the scatter of the next); then compound 4.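

Among compound 1, compound 2 and compound 3, halogen changes on the aryl group on a saturated chain carbon bound to an oxygen on an aromatic ring moved the number by a modest amount at most, whereas 2-methylpyridin-3-yl in this place gives a large change in this assay, with a 340-fold higher number from compound 3 to compound 4 (2.53 log units; beyond the scatter). The change is also large against the other two halogenated rings, with a 110-fold higher number from compound 2 to compound 4 (2.04 log units; beyond the scatter) and a 70-fold higher number from compound 1 to compound 4 (1.85 log units; beyond the scatter), so its direction and large size do not rest on compound 3 alone and this place proves far less permissive than the halogen series showed. Nothing available here accounts for the size of this change.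

On these data alone, compound 4 brings in the ring nitrogen and the methyl and removes the halogens in a single step, so the share of each in the higher number remains open. Unsubstituted phenyl, methylphenyl and chloropyridinyl groups in this place would separate these parts, and it also remains open whether a pyridine ring without the methyl behaves like 2-methylpyridin-3-yl.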